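Swapping a Hydroxyphenyl for a Dimethoxyphenyl on a Triazole

The source may report more compounds than this note shows. Statements on the series, on what has been measured and on what is new or still open speak of the compounds shown alone.

Measured so far:
- compound 1, `O=C(OCCCc1ccccc1)c1cc(-n2cc(-c3cccc(O)c3)nn2)ccc1O`: 9%
- compound 2, `COC(=O)c1cc(-n2cc(-c3cc(O)ccc3O)nn2)ccc1O`: 52%
- compound 3, `COc1ccc(-c2cn(-c3ccc(O)c(C(=O)Nc4cccc(C(F)(F)F)c4)c3)nn2)cc1`: 12%

In a functional assay on CCRF-CEM cells (Homo sapiens) for inhibition, read by MTT assay, with a stated time of 2 days, tested at 10 uM (on this read-out lower numbers stand for less inhibition and higher numbers for more inhibition at the one concentration tested (going by the name of the read-out)), compound 1 gives 9%. Compound 3 sits within the scatter of compound 1, so the two cannot be told apart, while compound 2 gives 52%, a number that lies well outside the scatter of both.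

The new compound 4, `COc1cc(OC)cc(-c2cn(-c3ccc(O)c(C(=O)OCCCc4ccccc4)c3)nn2)c1`, differs from compound 1 in one place: 3,5-dimethoxyphenyl in place of 3-hydroxyphenyl on an aromatic carbon. Among the compounds with values here, no pair of measured compounds shows this particular change, so the size of its step is unknown from the data. Within the data shown here, with compound 1 and compound 3 both at the low end of the read-out in this assay, and the only clearly higher number belonging to compound 2, which differs in several places at once, the step from compound 1 to compound 4 is expected to be small, most likely no larger than the scatter, in either direction.

Compound 4 is therefore estimated to give about 12% in this assay, between 0% and 35%, a step of a number 3 percentage points higher from compound 1 to compound 4 (within the scatter).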

Compound 4, a percentage reported as inhibition, at one concentration (the size of the read-out at that concentration, not a potency): 8%
Estimate against measurement, compound 4: 4 percentage points above; the measured number falls inside the stated range.
By their numbers in this assay, from the lowest: compounds 4, 1 and 3 (each within the scatter of the next); then compound 2.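

In this assay, within the data shown here, placing 3,5-dimethoxyphenyl in place of 3-hydroxyphenyl gives a number 1 percentage points lower from compound 1 to compound 4 (within the scatter), the first step in this set that can be read at a single place. The group that enters has no hydrogen-bond donor and more heavy atoms than the one that leaves, yet on an aromatic carbon of this five-membered aromatic ring with 3 nitrogen, the exchange produces no difference that can be told from the scatter. Nothing measured here explains this result.

From the compounds shown here alone, both compounds sit at the low end of the read-out, so it remains open whether the same exchange would also make no difference on a core that gives a higher number. Also open, going by these compounds, is how a phenyl ring carrying an amine or a carboxylic acid would read at this position.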